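A few compounds are considered here, and "the series" means these few. Any claim that something is new, unique, unknown or untested is made for them only; others in the source may bear on it.

Measured so far in an assay on isolated protein for inhibition of histone deacetylase HD1B (Zea mays); a lower number here means a stronger inhibitor, a higher number a weaker inhibitor:
compound 1 `Cn1cc(/C=C/C(=O)c2ccccc2)cc1/C=C/C(=O)NO` gives 260 nM;
compound 2 `Cn1cc(/C=C/C(=O)c2ccc(Cl)cc2)cc1/C=C/C(=O)NO` gives 29400 nM;
compound 3 `Cn1cc(/C=C/C(=O)c2ccc(F)cc2)cc1/C=C/C(=O)NO` gives 24900 nM.

Compound 3 sits second highest of the three numbers: compound 2 lies a 1.2-fold lower number from compound 2 to compound 3 (0.07 log units; within the scatter) away, compound 1 far lower at a 96-fold higher number from compound 1 to compound 3 (1.98 log units; beyond the scatter) reversed.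

Compound 4 `Cn1cc(/C=C/C(=O)c2ccc(-c3ccccc3)cc2)cc1/C=C/C(=O)NO` differs from compound 3 by phenyl in place of fluoro on an aromatic carbon, the site being on an aromatic carbon of a six-membered aromatic ring of carbon only, para to a large group.

Among the measured compounds shown here, no measured step exchanges one substituent at that carbon for another beyond a 1.2-fold lower number from compound 2 to compound 3 (0.07 log units; within the scatter), which stays within the scatter. The large steps of a 110-fold higher number from compound 1 to compound 2 (2.05 log units; beyond the scatter) and a 96-fold higher number from compound 1 to compound 3 (1.98 log units; beyond the scatter) concern hydrogen being replaced and do not cover phenyl entering. Compound 4 is therefore expected near compound 3, with the step of a 1.2-fold lower number from compound 3 to compound 4 (0.10 log units; within the scatter) estimated as small, direction uncertain. The estimate for compound 4 in this assay is 20000 nM, range 4000 nM to 80000 nM.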

Compound 4, half-maximal inhibitory concentration: 31800 nM
Compound 4: middle estimate off by 1.6-fold (0.20 log units), on the low side, and the stated range covers the measured number.
By their numbers in this assay, from the lowest: compound 1; then compounds 3, 2 and 4 (each within the scatter of the next).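

At this aromatic carbon, phenyl reads the same as the smaller substituents in this assay: a 1.3-fold higher number from compound 3 to compound 4 (0.11 log units; within the scatter) and a 1.1-fold higher number from compound 2 to compound 4 (0.03 log units; within the scatter) both stay within the scatter, although phenyl brings a whole ring. Fluoro, chloro and phenyl therefore do not separate from one another, while a 120-fold higher number from compound 1 to compound 4 (2.09 log units; beyond the scatter) shows that phenyl, like the other two, stands far from hydrogen. No supporting data bear on the reason for this gap. Open, going by these compounds, is whether an amine, a carboxylic acid or a methyl at this carbon would stay near compound 1 or join the other three.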